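This account rests on a few compounds, and the source may have more. Where it says the series, first, only, none or still open, it means among the compounds named here.

Measured compounds:
- compound 1 `COC(=O)/C=C/c1cccc(N(Cc2ccc(/C=C/c3scnc3C)cc2)C(=O)C2CCCCC2)c1` — in an assay on isolated protein with Bile acid receptor (Homo sapiens) as the target (on this read-out lower numbers stand for an effect already at smaller amounts and higher numbers for an effect only at larger amounts of compound), compound 1 gives 227 nM
- compound 2 `COC(=O)/C=C/c1cccc(N(Cc2ccc(Br)cc2)C(=O)C2CCCCC2)c1` — in this assay compound 2 gives > 1000 nM, which is a limit of the assay and not a number

Among the compounds with values here, compound 2 therefore stands only at a limit: of the two values shown, it is the one that did not resolve into a number, and the single measured step, an at least 4.4-fold higher number from compound 1 to compound 2 (0.64 log units; beyond the scatter), tells how it got there, as far as the limit allows (the limit of > 1000 nM in this assay, at which 1 of the 2 values shown sits).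

Compound 3 `COC(=O)/C=C/c1ccc(CN(C(=O)C2CCCCC2)c2cccc(/C=C/C(=O)OC)c2)cc1` differs from compound 2 by 2-(methoxycarbonyl)ethenyl in place of bromo on an aromatic carbon. Within the data shown here, no measured step covers this exact change. Among the measured compounds shown here, the only step that bears on it, an at least 4.4-fold higher number from compound 1 to compound 2 (0.64 log units; beyond the scatter), shows that replacing a larger group at this aromatic carbon with bromo lost activity beyond the limit; putting a chain back in place of bromo is the reverse kind of move, but with a different group, and the starting point is only a limit. Compound 3 is thus expected to move by an at least 1.1-fold lower number from compound 2 to compound 3 (0.04 log units; that floor lies within the scatter) in this assay, toward lower numbers, with wide uncertainty. Compound 3 is estimated at 900 nM, between 250 nM and 3500 nM.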

Compound 3, half-maximal effective concentration: > 1000 nM
Compound 3 ended at the assay's limit; the forecaster's own chance of this, stated with the estimate: 40%; at least 1.1-fold (0.04 log units) between middle value and limit.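

With 2-(methoxycarbonyl)ethenyl in place of bromo on this aromatic carbon, para to a large group, the reading in this assay still does not resolve into a number, and the step between the two limits cannot be read. The new compound keeps the double-bonded chain of compound 1 and changes only what stands at its end, with methoxycarbonyl in place of 4-methyl-1,3-thiazol-5-yl, and that single change gives an at least 4.4-fold higher number from compound 1 to compound 3 (0.64 log units; beyond the scatter). Within this pair, then, the chain alone does not retain the value of compound 1, and the group at its end makes a difference that compound 2 could not show, since that compound lacked the chain altogether; the comparison has only a one-sided reach: the limit of > 1000 nM in this assay, at which 2 of the 3 values shown sit.

On these data alone, how far compound 2 and compound 3 lie beyond that limit remains unknown, so bromo and 2-(methoxycarbonyl)ethenyl cannot be ranked against each other at this position. Also open, as far as these compounds go, is whether a carboxylic acid, an amine or a phenyl ring at the end of the chain, or a longer chain, would bring the reading in this assay back to a number.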